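Cyclohexyl for methyl on a ring amine: what to expect

The source may hold more compounds than are shown below. What is called first, only, known or untested is meant among the compounds shown, and "the series" means these compounds.

Compound 1 `Cc1ccc2c(NCc3ccc(NC(=O)C4CCN(Cc5ccc(F)cc5)CC4)cc3)nc(N(C)C)nc2c1` gives in a functional assay on SV5A8 cells (Homo sapiens) for cytotoxicity (on this read-out lower numbers stand for stronger inhibition and higher numbers for weaker inhibition), a limit of > 4820 nM.
Compound 2 `Cc1ccc(CN2CCC(C(=O)Nc3ccc(CNc4nc(N(C)C)nc5cc(C)ccc45)cc3)CC2)cc1` gives in this assay a limit of > 4150 nM.
Compound 3 `Cc1ccc2c(NCc3ccc(NC(=O)C4CCN(C)CC4)cc3)nc(N(C)C)nc2c1` gives in this assay a limit of > 17300 nM.

Compound 3 therefore stands among three compounds that all reach only a limit, so no number sets it apart from the other two. The change to compound 4 `Cc1ccc2c(NCc3ccc(NC(=O)C4CCN(C5CCCCC5)CC4)cc3)nc(N(C)C)nc2c1` is cyclohexyl in place of methyl on an amine nitrogen in a ring. Among the compounds with values here, the steps that bear on it, a step that the two limits leave unreadable from compound 1 to compound 3 and a step that the two limits leave unreadable from compound 2 to compound 3, put larger groups on the same nitrogen without yielding a readable number, and a step that the two limits leave unreadable from compound 1 to compound 2 is likewise unreadable. Within the data shown here, no measured step therefore gives a direction; a limit is expected again in this assay, and the estimated step of an at least 1.4-fold lower number from compound 3 to compound 4 (0.15 log units; that floor lies within the scatter) is none beyond the scatter. Compound 4 is expected at 12000 nM, between 3000 nM and 50000 nM.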

Compound 4, half-maximal inhibitory concentration: > 8320 nM
Compound 4: a limit, no number; the forecaster's own chance of this, stated with the estimate: 75%; the middle value does not contradict the limit.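

Compound 4, like compound 1, compound 2 and compound 3, gives only a limit in this assay, so no step among these four compounds can be read. On these data alone, whether any group on the ring nitrogen changes the actual number remains open.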